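Urea series: variation of the aryl-bound five-membered heterocycle

The compounds below may be only part of what the source reports. "The series", "measured", "known", "first", "only" and "open" are said of these compounds alone.

Compound 1 `Cc1cc(C)c(NC(=O)N(Cc2ccc(-c3nnc(C)o3)cc2)C2CCCCCC2)c(C)c1`: > 0.32 mg/kg
Compound 2 `Cc1cc(C)c(NC(=O)N(Cc2ccc(-c3ccn(C)n3)cc2)C2CCCCCC2)c(C)c1`: < 1 mg/kg

In a functional assay on a cell-free system (plasma) with sterol O-acyltransferase, Soat (Rattus norvegicus) as the target (a lower number here means that less compound is needed, a higher number that more compound is needed for the effect), compound 1 gives only a limit, > 0.32 mg/kg (the limit of > 0.32 mg/kg in this assay, at which 1 of the 2 values shown sits). Compound 2 likewise gives only a limit in this assay, < 1 mg/kg, so its standing among the two values shown is not a number (the limit of < 1 mg/kg in this assay, at which 1 of the 2 values shown sits). Among the compounds with values here, the single measured step, a step that the limit leaves unreadable from compound 1 to compound 2, is left unreadable by the limits, so no step size for changing this heterocycle is known. Compound 3 `Cc1cc(C)c(NC(=O)N(Cc2ccc(-n3cncn3)cc2)C2CCCCCC2)c(C)c1` differs from compound 2 by 1H-1,2,4-triazol-1-yl in place of 1-methyl-1H-pyrazol-3-yl on an aromatic carbon. Lacking any readable step, the expected step that the limit leaves unreadable from compound 2 to compound 3 in this assay is set near none. Compound 3 is estimated at 0.5 mg/kg in this assay, with a range from 0.1 mg/kg to 3 mg/kg.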

Compound 3, dose for half-maximal effect: > 1 mg/kg
Compound 3 was reported as a limit; the forecaster's own chance of this, stated with the estimate: 50%; middle value at least 2.0-fold (0.30 log units) from the limit.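

In this assay, replacing 1-methyl-1H-pyrazol-3-yl with 1H-1,2,4-triazol-1-yl on this aromatic carbon, para to a large group, gives the only readable direction at this position: a number no lower from compound 2 to compound 3 (the limit leaves the size open). Compound 3 gives a limit, not a number: the limit of > 1 mg/kg in this assay, at which 1 of the 3 values shown sits. The steps involving compound 1 cannot be read, so 5-methyl-1,3,4-oxadiazol-2-yl remains unplaced relative to the other two groups.

As far as these compounds go, the size of the change from the pyrazole to the triazole remains open. Also open, from the compounds shown here alone, is where a simple amine or a carboxylic acid would fall at this position.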